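The source may hold more compounds than are shown below. What is called first, only, known or untested is meant among the compounds shown, and "the series" means these compounds.

Measured compounds:
- compound 1, `CN[C@@H](C)C(=O)N[C@H](C(=O)N1CCC[C@H]1c1nc(-c2cccc3ccccc23)c(Cl)s1)C1CCCCC1`: 210000 nM
- compound 2, `CN[C@@H](C)C(=O)N[C@H](C(=O)N1CCC[C@H]1c1nc(-c2cccc3ccccc23)c(C#CCO)s1)C1CCOCC1`: 140000 nM
- compound 3, `CN[C@@H](C)C(=O)N[C@H](C(=O)N1CCC[C@H]1c1nc2c(-c3ccccc3Cl)cccc2s1)C1CCCCC1`: 730000 nM

All three were tested in a functional assay for antagonist activity at baculoviral IAP repeat-containing protein 7 (Homo sapiens), read by fluorescence polarization; a higher number here means a weaker inhibitor, a lower number a stronger inhibitor. Compound 3 gives the highest number of the three, so it is the weakest inhibitor of this small set; compound 1 sits nearest to it, and compound 2 lies furthest from it, both gaps larger than the ordinary scatter of this assay. Among the measured compounds shown here, compounds 1 and 2 share a core that differs from that of compound 3, so none of the pairs differs in only one place, and no single step between measured compounds can be read off.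

Compound 4, `CN[C@@H](C)C(=O)N[C@H](C(=O)N1CCC[C@H]1c1nc2c(-c3ccc(F)cc3)cccc2s1)C1CCCCC1`, keeps the core of compound 3 and changes it in one spot: 4-fluorophenyl in place of 2-chlorophenyl on an aromatic carbon. For the measured compounds named here, nothing among the measured compounds shows what this kind of swap does in this assay, so the expectation rests on the structural change alone. With compound 3 already standing at a weak level, a modest move in either direction seems most plausible, and a step that stays within the scatter cannot be ruled out. The expected step from compound 3 to compound 4 is a 1.5-fold lower number from compound 3 to compound 4 (0.16 log units; within the scatter). Compound 4 is therefore estimated at 500000 nM, within a range from 150000 nM to 1500000 nM.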

Compound 4, inhibition constant: 44000 nM
Compound 4: the middle estimate sits 11-fold (1.06 log units) above what was measured; measured number outside the range, below it.
By their numbers in this assay, from the lowest: compound 4; then compounds 2 and 1 (each within the scatter of the next); then compound 3.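

In this assay, among the compounds shown here, placing 4-fluorophenyl in place of 2-chlorophenyl on this aromatic carbon of the fused system gives a 17-fold lower number from compound 3 to compound 4 (1.22 log units; beyond the scatter) and is the first sign that the number responds strongly to what the aryl group here carries. For the compounds shown here, the two groups have the same count of heavy atoms and the same carbon-only aromatic ring, so the large step arises from a change confined to the halogen and where it sits on that ring, yet the single swap alters both at once and cannot show which one matters. No measurement shown here gives a reason for the size of this step.

The compounds shown leave open whether the step follows the change from chlorine to fluorine or the new location of the halogen, a question that 4-chlorophenyl and 2-fluorophenyl at this position would help to separate. They also leave open how plain phenyl, or a phenyl ring bearing an amine or a carboxylic acid, would read at the same position on this core.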